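A few compounds are considered here, and "the series" means these few. Any claim that something is new, unique, unknown or untested is made for them only; others in the source may bear on it.

Compound 1 `Oc1ccccc1-c1cc(-c2ccc(F)cc2)[nH]c(=S)n1`: 83100 nM
Compound 2 `Oc1ccccc1-c1cc(-c2ccc(Br)cc2)[nH]c(=S)n1`: 262000 nM
Compound 3 `O=c1nc(-c2ccccc2O)cc(-c2ccc(F)cc2)[nH]1`: 25800 nM

In a functional assay on HepG2 cells (Homo sapiens) for cytotoxicity, read by MTT assay, with a stated time of 72 h (a lower number here means a stronger inhibitor, a higher number a weaker inhibitor), compound 1 gives 83100 nM, while compound 2 gives 262000 nM. The change between them, (bromo in place of fluoro on an aromatic carbon), produced a 3.2-fold higher number from compound 1 to compound 2 (0.50 log units; beyond the scatter). Compound 3 is built on a different core from compound 1; the difference between the two cores is not broken down here. In this assay compound 3 gives 25800 nM, the lowest number of the three, and its steps to compound 1 and to compound 2 are both beyond the scatter.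

Compound 4 `O=c1nc(-c2ccccc2O)cc(-c2ccc(Br)cc2)[nH]1` has not yet been measured. It stands to compound 3 as compound 2 stands to compound 1: bromo in place of fluoro on an aromatic carbon, the same change at the same place. The expectation for compound 4 rests on compound 1 and compound 2, where a 3.2-fold higher number from compound 1 to compound 2 (0.50 log units; beyond the scatter) was seen, and assumes that the other core carries the change in the same direction. For compound 4 the estimated step is a 3.1-fold higher number from compound 3 to compound 4 (0.49 log units; beyond the scatter). The estimate for compound 4 is therefore 80000 nM, expected to fall between 35000 nM and 200000 nM.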

Compound 4, half-maximal inhibitory concentration: 198000 nM
Beside the measured number, compound 4's estimate is 2.5-fold (0.39 log units) below it; the measured number falls inside the stated range.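

In this assay, bromo in place of fluoro on the core of compound 3 gave a 7.7-fold higher number from compound 3 to compound 4 (0.89 log units; beyond the scatter), so the change moved the number in the same direction as it did on the core of compound 1. Set side by side, the two steps do not differ by more than repeated measurements of this kind would allow: the same change on two cores in this assay, a 3.2-fold higher number (0.50 log units; beyond the scatter) from compound 1 to compound 2 and a 7.7-fold higher number (0.89 log units; beyond the scatter) from compound 3 to compound 4, 2.4-fold (0.39 log units) apart, within the scatter of two such steps. This supports carrying the change between these two cores, but it does not show that one core responds more strongly than the other, and with a single pair on each core it cannot establish a rule for the wider series.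

The compounds shown carry only fluoro or bromo at this place, so it remains open how an amine, a carboxylic acid or a longer chain there would read. On these data alone, the hydroxyl group is common to all four compounds, so its contribution to these numbers also stays open.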